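Methoxy for Chloro: Cytotoxicity Expected to Stay at the Limit

A few compounds are considered here, and "the series" means these few. Any claim that something is new, unique, unknown or untested is made for them only; others in the source may bear on it.

Compound 1, `O=C(c1ccc2c(c1)OCCO2)C1CCN(Cc2coc(-c3ccc(Cl)cc3)n2)CC1`, was examined in an ADME assay on HEK293 cells (Homo sapiens) for cytotoxicity, read by MTT assay, with a stated time of 36 h; a higher number here means a weaker inhibitor, a lower number a stronger inhibitor. In this assay compound 1 gives > 150 ug/mL, which is a limit of the assay and not a measured number. Compound 2, `O=C(c1ccc2c(c1)OCCO2)C1CCN(Cc2coc(-c3ccc(Br)cc3)n2)CC1`, gives > 150 ug/mL in this assay, again a limit. Compound 3, `O=C(c1ccc2c(c1)OCCO2)C1CCN(Cc2coc(-c3ccccc3F)n2)CC1`, gives > 150 ug/mL in this assay, also a limit. The steps a step that the two limits leave unreadable from compound 1 to compound 2, a step that the two limits leave unreadable from compound 1 to compound 3 and a step that the two limits leave unreadable from compound 2 to compound 3 therefore cannot be sized; all three compounds share (the limit of > 150 ug/mL in this assay, at which 3 of the 3 values shown sit).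

Compound 4, `COc1ccc(-c2nc(CN3CCC(C(=O)c4ccc5c(c4)OCCO5)CC3)co2)cc1`, differs from compound 1 by methoxy in place of chloro on an aromatic carbon. The steps from compound 1 to compound 2 and from compound 1 to compound 3 touch the same aryl group, but none of them yields a readable size, so there is no basis for expecting a step beyond the scatter in either direction. Compound 4 is therefore expected to give 200 ug/mL, with a range from 110 ug/mL to 400 ug/mL, most probably reported again only as a limit. The expected step that the limit leaves unreadable from compound 1 to compound 4 is estimated to be negligible.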

Compound 4, half-maximal inhibitory concentration: > 150 ug/mL
Compound 4 was reported as a limit (the forecaster's own chance of this, stated with the estimate: 85%); the middle value is on the limit's open side.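

No step from compound 1, compound 2 or compound 3 to compound 4 can be read, since all four compounds stand at a limit of the assay and not at a number: the limit of > 150 ug/mL in this assay, at which 4 of the 4 values shown sit.

The compounds shown leave open whether changing the aryl group alters the read-out in this assay at all.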